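A few compounds are considered here, and "the series" means these few. Any claim that something is new, unique, unknown or untested is made for them only; others in the source may bear on it.

In a functional assay on HEK293 cells for antagonist activity at thromboxane A2 receptor (Homo sapiens), read by fluorescence and calcium flux (a higher number here means a weaker inhibitor, a lower number a stronger inhibitor), the series so far:
compound 1 `Cc1ccccc1Oc1ccc(C#N)cc1S(=O)(=O)NC(=O)NC(C)C` gives 8680 nM;
compound 2 `CC(C)NC(=O)NS(=O)(=O)c1cc(C#N)ccc1Oc1ccc(Cl)cc1` gives 9460 nM;
compound 3 `Cc1cccc(Nc2ccc(C#N)cc2S(=O)(=O)NC(=O)NC(C)C)c1` gives 9500 nM.

Compound 3 lies within the scatter of both others, as the steps of a 1.1-fold higher number from compound 1 to compound 3 (0.04 log units; within the scatter) and a 1.0-fold higher number from compound 2 to compound 3 (0.00 log units; within the scatter) show; none of the three numbers can be ordered against another. Compound 4 `CC(C)NC(=O)NS(=O)(=O)c1cc(C#N)ccc1Nc1ccc(F)cc1` differs from compound 3 by 4-fluorophenyl in place of 3-methylphenyl on a nitrogen on an aromatic ring. Within the data shown here, the one measured step that swaps only the group on the oxygen, a 1.1-fold higher number from compound 1 to compound 2 (0.04 log units; within the scatter), sits within the scatter, and the two steps that also exchange the oxygen for nitrogen do the same. Nothing measured points to a move beyond the scatter in this assay. Compound 4 is therefore expected to give about 9500 nM, with a range of 4000 nM to 22000 nM. The expected step is no change at the digits printed from compound 3 to compound 4 (within the scatter).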

Compound 4, half-maximal inhibitory concentration: 8170 nM
The estimate for compound 4 lay 1.2-fold (0.07 log units) above the measured number; the range from low to high includes it.
By their numbers in this assay, from the lowest: compounds 4, 1, 2 and 3 (each within the scatter of the next).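

In this assay, among these compounds, 4-fluorophenyl in place of 3-methylphenyl is the first change of the aryl group with the nitrogen link held constant, and it stays within the scatter (a 1.2-fold lower number from compound 3 to compound 4 (0.07 log units; within the scatter)). The two steps that also exchange the oxygen link for nitrogen do the same (a 1.2-fold lower number from compound 2 to compound 4 (0.06 log units; within the scatter); a 1.1-fold lower number from compound 1 to compound 4 (0.03 log units; within the scatter)). Across these compounds, neither a fluorine on this ring nor the choice of link separates any value, and nothing available accounts for this.

Open, as far as these compounds go, is whether a carboxylic acid on this ring, or a longer chain in its place, would move the number beyond the scatter. From the compounds shown here alone, the isopropyl group, common to all four compounds, also remains untested by any step.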